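The compounds below may be only part of what the source reports. "The series", "measured", "known", "first", "only" and "open" are said of these compounds alone.

Working notes on the series.

Three members carry the same amide-bearing sugar core. Compound 1 `C=CCCC(=O)N[C@H]1[C@@H](OCCCCCCCCCCCCCCCC)O[C@H](CO)[C@@H](O)[C@@H]1O` bears a long-chain ether and a hydroxymethyl without further substitution. Compound 2 `CCCCC(=O)N[C@H]1[C@@H](OCCc2ccccc2)O[C@H](COCC(CO)(CO)COS(=O)(=O)O)[C@@H](O)[C@@H]1O` and compound 3 `CCCCCCCCCCCCCCCCO[C@H]1O[C@H](COCC(CO)(CO)COS(=O)(=O)O)[C@@H](O)[C@H](O)[C@H]1NC(=O)CCCC` both carry a sulfooxy-bearing branched ether on the hydroxymethyl position, differing from each other in the ether on the anomeric oxygen and in the amide chain.

In a functional assay on C6 cells (Rattus norvegicus), read by thymidine incorporation (a lower number here means a stronger inhibitor, a higher number a weaker inhibitor), compound 2 gives 8.6 uM. Compound 3 gives 11 uM in this assay, and the two numbers lie within the scatter of each other, so no order between them can be read. For compound 1 this assay reports only a limit, > 50 uM (the limit of > 50 uM in this assay, at which 1 of the 3 values shown sits).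

Compound 4 `CCCCC(=O)N[C@H]1[C@@H](OCCc2ccccc2)O[C@H](COCC(CO)(CO)CO)[C@@H](O)[C@@H]1O` is not yet measured. It differs from compound 2 in one place: hydrogen in place of sulfo on an oxygen on a saturated carbon. Among the compounds with values here, no measured pair in the set isolates this change. Within the data shown here, the only member without a sulfo group, compound 1, also differs in the anomeric ether and the amide chain, so its limit cannot be laid on this step alone; it does, though, point toward weaker inhibition once the sulfo group is gone.

The step of a 3.5-fold higher number from compound 2 to compound 4 (0.54 log units; beyond the scatter) is therefore expected to go toward a higher number, beyond the scatter. Compound 4 is expected to give 30 uM, with a range from 10 uM to 100 uM.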

Compound 4, concentration for 50% inhibition: > 50 uM
Compound 4 ended at the assay's limit (the forecaster's own chance of this, stated with the estimate: 30%); at least 1.6-fold (0.22 log units) between middle value and limit.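

Within the data shown here, the step of an at least 5.8-fold higher number from compound 2 to compound 4 (0.76 log units; beyond the scatter) in this assay isolates, for the first time, hydrogen in place of sulfo on an oxygen on a saturated carbon, with the rest of the structure held constant. Earlier, the sulfo-free compound 1 could say nothing about this change alone, as it differs from the sulfated members in more than one place; this single-place pair shows that inhibition here depends on the sulfo group on this branched ether. In this assay compound 4 gives > 50 uM, which is a limit of the assay and not a number, so the step gives only a lower bound on the loss and its true size stays unknown: the limit of > 50 uM in this assay, at which 2 of the 4 values shown sit.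

The compounds shown leave open whether the same change has a step of similar size with the long-chain ether and amide of compound 3. They also leave open whether another group on this oxygen, such as a phosphate or a carboxylic acid on a short chain, would hold the inhibition seen with sulfo.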